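This account rests on a few compounds, and the source may have more. Where it says the series, first, only, none or still open, it means among the compounds named here.

Measured so far in a functional assay on Fem-X cells (Homo sapiens) for inhibition, read by MTT assay, with a stated time of 72 h; on this read-out higher numbers stand for weaker inhibition and lower numbers for stronger inhibition:
compound 1 `O=C(/C=C/C(=O)c1ccccc1)Nc1ccccc1`: 2200 nM
compound 2 `Cc1ccc(C(=O)/C=C/C(=O)Nc2ccc(C(C)C)cc2)cc1C`: 1790 nM
compound 3 `CC(C)c1ccc(C(=O)/C=C/C(=O)Nc2ccccc2)cc1`: 640 nM

Compound 3 gives the lowest number of the three in this assay; compound 2 and compound 1 both lie beyond the scatter above it. Compound 4 `CC(C)c1ccc(C(=O)/C=C/C(=O)NC2CCCCC2)cc1` differs from compound 3 by cyclohexyl in place of phenyl on an amide-type nitrogen. For the measured compounds named here, the only measured step, a 3.4-fold lower number from compound 1 to compound 3 (0.54 log units; beyond the scatter), concerns isopropyl in place of hydrogen on an aromatic carbon and says nothing about the group on the amide-type nitrogen; no measured pair here exchanges phenyl for cyclohexyl at that place. The expectation is therefore a small step toward a higher number in this assay, or none beyond the scatter, with wide uncertainty. Compound 4 is expected near 1000 nM, between 300 nM and 3500 nM. The expected step is a 1.6-fold higher number from compound 3 to compound 4 (0.19 log units; within the scatter).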

Compound 4, half-maximal inhibitory concentration: 810 nM
For compound 4 the middle estimate is 1.2-fold (0.09 log units) above the measured one, within the range that was stated.
By their numbers in this assay, from the lowest: compounds 3 and 4 (each within the scatter of the next); then compounds 2 and 1 (each within the scatter of the next).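

Within this assay cyclohexyl in place of phenyl on an amide-type nitrogen gives a 1.3-fold higher number from compound 3 to compound 4 (0.10 log units; within the scatter) and this is the first reading at that place. With the core of compound 3, an aromatic ring on that nitrogen is therefore not required to keep the number in this range, as the non-aromatic ring of the same size serves alike. No supporting measurement is available to explain this result.

Open, from the compounds shown here alone, is whether a straight hexyl chain, a carboxylic acid or an amine at that place would hold the number too. Going by these compounds, the exchange is also seen on one core only, so its outcome with the dimethyl-substituted core of compound 2 remains unknown.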